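A Second Chloro Group on a Shared Core

This account rests on a few compounds, and the source may have more. Where it says the series, first, only, none or still open, it means among the compounds named here.

Of the compounds shown here, three have been measured in an assay on CHO cells for displacement of a labelled ligand from adenosine receptor A3 (Homo sapiens), read by scintillation counting, tested at 10 uM; on this read-out lower numbers stand for less inhibition and higher numbers for more inhibition at the one concentration tested (going by the name of the read-out). Compound 1 `CC(C)(C)Cc1c(-c2ccc(Cl)cc2)sc(N)c1C(=O)c1ccc(Cl)cc1` gives 1% in this assay. Compound 2 `CC(C)(C)Cc1c(-c2ccc(Cl)c(Cl)c2)sc(N)c1C(=O)c1ccc(Cl)cc1` differs from compound 1 in one place: chloro in place of hydrogen on an aromatic carbon. In this assay compound 2 gives 1%, and the step of no change at the digits printed from compound 1 to compound 2 (within the scatter) shows that the added chloro group leaves the read-out where it was. Compound 3 `CC(C)(C)Cc1c(Br)sc(N)c1C(=O)c1cccc(Cl)c1` is built on a different core; the difference between the two cores is not broken down here. In this assay compound 3 gives 1%, level with compounds 1 and 2.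

Compound 4 `CC(C)(C)Cc1c(Br)sc(N)c1C(=O)c1ccc(Cl)c(Cl)c1` has not yet been measured. It is made from compound 3 by the difference (chloro in place of hydrogen on an aromatic carbon). Within the data shown here, this is the same kind of change as the one leading from compound 1 to compound 2, but not the same change: in compound 2 the entering chloro group sits meta to a large group, whereas in compound 4 it sits para to a large group.

Because the step of no change at the digits printed from compound 1 to compound 2 (within the scatter) stayed within the scatter, and because compound 3 gives 1%, the same kind of addition is expected to move the read-out by no more than no change at the digits printed from compound 3 to compound 4 (within the scatter). Compound 4 is therefore expected to give 1% in this assay, with an expected range from 0% to 10%.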

Compound 4, a percentage reported as inhibition, at one concentration (the size of the read-out at that concentration, not a potency): 1%
Compound 4: middle estimate and measured number agree at the digits printed; the measured number falls inside the stated range.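

In this assay the new step reads no change at the digits printed from compound 3 to compound 4 (within the scatter), and set beside the earlier step it agrees with it: the same change on two cores in this assay, no change at the digits printed (within the scatter) from compound 1 to compound 2 and no change at the digits printed (within the scatter) from compound 3 to compound 4, 0 percentage points apart, within the scatter of two such steps. On these two cores, then, chloro in place of hydrogen on an aromatic carbon behaves alike, leaving the read-out where it was, even though the entering chloro group does not sit in the same place in the two steps. Among these compounds, this does not show that the change would carry over to other cores or to compounds with a different read-out: there are only two cores here, compound 4 gives 1%, level with the other three compounds, and a change that leaves the number unmoved on both cores is a weak test of transfer, since a step that moved the read-out could be checked for size and direction, and a single tested concentration says nothing about potency.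

The compounds shown leave open whether a group other than a halogen on these aromatic rings, such as a methoxy group, a nitrile or a carboxylic acid, would move the read-out at all. They also leave open whether changing the free amine, for example to an amide, would do so on either core.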